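The compounds below may be only part of what the source reports. "The series", "measured", "known", "first", "only" and "open" are said of these compounds alone.

Compound 1 `N#CC1=C(N)N(c2ccc(S(N)(=O)=O)cc2)C2=C(CCCC2)C1/C=C/c1ccccc1` gives 50% in a functional assay on Ehrlich cells (Mus musculus) for cytotoxicity, read by trypan blue exclusion, with a stated time of 2 h, tested at 10 ug/mL; on this read-out lower numbers stand for a weaker effect and higher numbers for a stronger effect at the one concentration tested. Of the two numbers shown it stands highest; the nearest is compound 2 `COc1ccc2ccccc2c1C1C(C#N)=C(N)N(c2ccc(S(N)(=O)=O)cc2)C2=C1CCCC2`, which in this assay gives 5%, a gap that lies beyond the usual scatter of repeated measurements.

Compound 3 `Cc1ccc(C2C(C#N)=C(N)N(c3ccc(S(N)(=O)=O)cc3)C3=C2CCCC3)o1` has not yet been measured in this assay. It differs from compound 1 in one place: 5-methylfuran-2-yl in place of 2-phenylethenyl on a saturated ring carbon. Among the measured compounds shown here, no step between measured compounds isolates this change, so the expectation can rest only on the two values shown. For the measured compounds named here, because compound 2 gives 5% in this assay, the only other number recorded, a downward step beyond the scatter is expected here rather than none. The step of a number 30 percentage points lower from compound 1 to compound 3 (beyond the scatter) is the size that the estimate implies. Compound 3 is expected to give 20% in this assay, within a range from 5% to 45%.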

Compound 3, a percentage reported as activity, at one concentration (the size of the read-out at that concentration, not a potency): 0%
The estimate for compound 3 lay 20 percentage points above the measured number; measured number outside the range, below it.
By their numbers in this assay, from the lowest: compounds 3 and 2 (each within the scatter of the next); then compound 1.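

In this assay, the step of a number 50 percentage points lower from compound 1 to compound 3 (beyond the scatter) shows that the read-out at this saturated ring carbon does not survive this exchange: with 5-methylfuran-2-yl in place of 2-phenylethenyl, nothing remains of the effect seen with compound 1. Compound 3 at 0% and compound 2 at 5% lie within the scatter of each other, so among these three compounds, two different replacements of 2-phenylethenyl at this carbon both end at low numbers, and only compound 1 keeps a clear effect. No measurement shown here accounts for this loss.

The compounds shown leave open whether the double bond outside the aromatic rings or the carbon-only six-membered ring of 2-phenylethenyl matters more. A 2-phenylethyl chain or a plain phenyl group at this carbon would separate the two.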